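Swapping Chloro for Fluoro on Two Different Rings

The compounds below may be only part of what the source reports. "The series", "measured", "known", "first", "only" and "open" are said of these compounds alone.

Of the compounds shown here, three have been measured in an ADME assay on Left cardiac atrium (Cavia porcellus) (a lower number here means that less compound is needed, a higher number that more compound is needed for the effect), and a fourth awaits its number. Compound 1 `CCOC(=O)C1=C(C)NC(C)=C(C(=O)OCC)C1c1c(-c2ccc(F)cc2)nc2sccn12` and compound 2 `CCOC(=O)C1=C(C)NC(C)=C(C(=O)OCC)C1c1c(-c2ccc(Cl)cc2)nc2sccn12` share a core and differ only in a single halogen on a six-membered aromatic ring. In this assay compound 1 gives 64 nM, and compound 2 gives 97 nM. The step between them, a 1.5-fold lower number from compound 2 to compound 1 (0.18 log units; within the scatter), comes from fluoro in place of chloro on an aromatic carbon.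

Compound 3 `CCOC(=O)C1=C(C)NC(C)=C(C(=O)OCC)C1c1c(-c2ccc([N+](=O)[O-])cc2)nc2sc(Cl)cn12` carries a different core; the difference between the core of compound 3 and the core of compound 2 is not broken down here. In this assay, for the measured compounds named here, compound 3 gives 1370 nM, the highest of the three numbers measured so far.

Compound 4 `CCOC(=O)C1=C(C)NC(C)=C(C(=O)OCC)C1c1c(-c2ccc([N+](=O)[O-])cc2)nc2sc(F)cn12` has not yet been measured. It differs from compound 3 by fluoro in place of chloro on an aromatic carbon. Going by the values given here, this is the same kind of change as the one from compound 2 to compound 1, but not the same: there the halogen sat on a six-membered aromatic ring of carbon only, para to a large group, while here it sits on a five-membered aromatic ring with 1 nitrogen and 1 sulfur, part of a fused system of two rings, next to the ring sulfur.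

Because the earlier swap produced a 1.5-fold lower number from compound 2 to compound 1 (0.18 log units; within the scatter), a step within the scatter, a similarly small step is expected here as well, namely a 1.4-fold lower number from compound 3 to compound 4 (0.14 log units; within the scatter). The estimate for compound 4 in this assay is therefore 1000 nM, expected to fall between 400 nM and 2500 nM.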

Compound 4, half-maximal effective concentration: 24 nM
Compound 4: middle estimate off by 42-fold (1.62 log units), on the high side, outside the stated range (below it).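

In this assay the swap of chloro for fluoro on an aromatic carbon of the five-membered ring, next to the ring sulfur, gives a 57-fold lower number from compound 3 to compound 4 (1.76 log units; beyond the scatter) and is a large step, so the same named change does not keep its size from one core to the other: the same change on two cores in this assay, a 1.5-fold lower number (0.18 log units; within the scatter) from compound 2 to compound 1 and a 57-fold lower number (1.76 log units; beyond the scatter) from compound 3 to compound 4, 38-fold (1.58 log units) apart, beyond the scatter of two such steps. In practice, a small step seen on the six-membered ring of one core was a poor guide to the step on the five-membered ring of another, and a matched swap in this series cannot simply be copied across cores with its size intact. What this does not show is which difference matters, since the two swaps differ both in where the halogen sits and in the rest of the molecule, and with a single pair for each case these two differences cannot be separated, nor can a general rule for fluoro over chloro be drawn.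

The compounds shown leave open whether the large step would remain if the nitro group on the six-membered ring gave way to a fluoro or chloro group. They also leave open how a bromo or a methyl group next to the ring sulfur would compare with the two halogens tested there.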